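The source may hold more compounds than are shown below. What is called first, only, known or untested is meant among the compounds shown, and "the series" means these compounds.

In a functional assay on HCT-116 cells (Homo sapiens) for inhibition, read by CCK-8 assay, with a stated time of 48 h (on this read-out higher numbers stand for weaker inhibition and lower numbers for stronger inhibition), the measured compounds stand as follows.

- compound 1 `COc1cc(-c2ccnc3cc(-c4c[nH]c5ccccc45)nn23)cc(OC)c1OC` gives 35 nM as a number
- compound 2 `COc1cc(-c2ccnc3cc(-c4ccc(C)cc4)nn23)cc(OC)c1OC` gives 48 nM as a number
- compound 3 `COc1cc(-c2ccnc3cc(-c4cccc(C#N)c4)nn23)cc(OC)c1OC` gives > 10000 nM as a limit of the assay, not a number

Compound 3 therefore has no number of its own, only the limit of > 10000 nM in this assay, at which 1 of the 3 values shown sits, to mark its place.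

Compound 4 `COc1cc(-c2ccnc3cc(-c4ccc(N(C)C)cc4)nn23)cc(OC)c1OC` carries 4-(dimethylamino)phenyl in place of 3-cyanophenyl on an aromatic carbon. In the change 4-(dimethylamino)phenyl in place of 3-cyanophenyl on an aromatic carbon the shared core stays the same.

Among the measured compounds shown here, three measured steps bear on this change. The exchange at this carbon gave a 1.4-fold higher number from compound 1 to compound 2 (0.14 log units; within the scatter) and so stayed within the scatter, while an at least 200-fold higher number from compound 2 to compound 3 (2.31 log units; beyond the scatter) and an at least 280-fold higher number from compound 1 to compound 3 (2.45 log units; beyond the scatter) are both large. Among these three compounds, only the 3-cyanophenyl of compound 3 goes with a large step.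

For the measured compounds named here, the 4-(dimethylamino)phenyl of compound 4 has the form of the 4-methylphenyl of compound 2 at 48 nM and so compound 4 is expected near that level, though with a wide margin because no measured compound carries this group. A large step toward lower numbers, meaning stronger inhibition, is expected, and an at least 110-fold lower number from compound 3 to compound 4 (2.04 log units; beyond the scatter) is its estimated size. Compound 4 is estimated at 90 nM and expected between 20 nM and 700 nM on present evidence.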

Compound 4, half-maximal inhibitory concentration: 2050 nM
Compound 4: middle estimate off by 23-fold (1.36 log units), on the low side, and the stated range ends below it.
By their numbers in this assay, from the lowest: compounds 1 and 2 (each within the scatter of the next); then compound 4. At a limit, above all of these: compound 3.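

In this assay, the position on the aromatic carbon of the five-membered ring turns out to respond to more than the 3-cyanophenyl group alone: dimethylamino in place of methyl on the phenyl ring gives a 43-fold higher number from compound 2 to compound 4 (1.63 log units; beyond the scatter). Compound 4 also separates from the indole of the series, with a 59-fold higher number from compound 1 to compound 4 (1.77 log units; beyond the scatter), so a phenyl ring at this carbon does not by itself hold the level shared within the scatter by compounds 1 and 2, and the group that the ring carries counts. Compound 3 stands only at a limit of the assay, not at a number, so an at least 4.8-fold lower number from compound 3 to compound 4 (0.68 log units; beyond the scatter) gives a minimum size for this change: the limit of > 10000 nM in this assay, at which 1 of the 4 values shown sits.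

As far as these compounds go, whether the loss follows dimethylamino specifically or extends to other groups in its place stays open; a primary amine or a methoxy group on the same ring would separate these readings. Compounds 3 and 4 also differ in both the group and its place on the phenyl ring, and 4-cyanophenyl would show how much of the gap belongs to the nitrile itself.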